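The source may report more compounds than this note shows. Statements on the series, on what has been measured and on what is new or still open speak of the compounds shown alone.

Measured compounds:
compound 1, `CC(=O)SCCC(CCCCC(=O)Nc1ccccc1)SC(C)=O`: 44.8%
compound 2, `CC(=O)SCCC(CCCCC(=O)Nc1cccc(Cl)c1)SC(C)=O`: 42.8%
compound 3, `O=C(CCCCC(CCSC(=O)c1ccccc1)SC(=O)c1ccccc1)Nc1ccccc1`: "not active" (no number reported)

In a functional assay on NCI-H460 cells (Homo sapiens) for inhibition, read by MTT assay, with a stated time of 24 h, tested at 100 ug/mL (a lower number here means less inhibition of growth, a higher number more inhibition of growth at the concentration tested), compound 1 gives 44.8%. Compound 2 gives 42.8% in this assay. Compound 2 differs from compound 1 by chloro in place of hydrogen on an aromatic carbon. The step is a number 2 percentage points lower from compound 1 to compound 2 (within the scatter), so the two values are not distinguishable.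

Compound 3 has a different core; the difference between the two cores is not broken down here. In this assay compound 3 returned no number and was recorded as not active.

Compound 4, `O=C(CCCCC(CCSC(=O)c1ccccc1)SC(=O)c1ccccc1)Nc1ccccc1Cl`, is not yet measured. It differs from compound 3 by chloro in place of hydrogen on an aromatic carbon. The place is not identical to that in compound 2: in compound 2 the chlorine stands meta to a large group, in compound 4 ortho to a large group, so this is the same kind of change, not the same change. Going by the values given here, the one measured example of this kind, from compound 1 to compound 2, was a number 2 percentage points lower from compound 1 to compound 2 (within the scatter), within the scatter, and a step of similar small size is expected from compound 3 to compound 4. Because compound 3 is recorded as "not active" (no number reported) rather than with a number, the step can only be anchored to that record, so compound 4 is expected to sit low as well, and there is a fair chance it is again reported without a number.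

Compound 4 is expected at about 10% in this assay, within roughly 0% to 30%.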

Compound 4, percent growth inhibition at one concentration: "not active" (no number reported)
Compound 4: no number reported; the estimate stays without a comparison.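

In this assay, going by these compounds alone, compound 3 and compound 4 are both recorded without a number, so no step between them can be read. Nothing measured here bears on this outcome. The compounds shown leave open whether chloro in place of hydrogen has any effect on growth inhibition with the core of compound 3, and how that core compares numerically with the core of compound 1.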